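The source may hold more compounds than are shown below. What is called first, only, known or untested is meant among the compounds shown, and "the series" means these compounds.

In a functional assay on THP-1 cells (Homo sapiens) for inhibition, read by sulforhodamine B assay, with a stated time of 48 h (a lower number here means a stronger inhibitor, a higher number a weaker inhibitor), compound 1 `COc1ccc(/C(=N/OC(C)=O)c2cccc3ccccc23)c(OC)c1OC` gives > 20000 nM, which is a limit of the measurement rather than a number. A second compound, compound 2 `C=CCC(O)(c1ccc(OC)c(OC)c1OC)c1cccc2ccccc12`, also gives > 20000 nM in this assay, again a limit and not a number. Both results therefore rest on the same boundary, where no ordering between them is possible: the limit of > 20000 nM in this assay, at which 2 of the 2 values shown sit. The unmeasured compound 3 `CCOC(=O)/C=C/CO/N=C(/c1ccc(OC)c(OC)c1OC)c1cccc2ccccc12` is reached from compound 1 by a single change, (3-(ethoxycarbonyl)prop-2-en-1-yl in place of acetyl on an oxygen), placed on an oxygen whose other neighbours are double-bonded nitrogen. For the measured compounds named here, no step between two fully measured compounds exists in this set, so there is no measured guide to how far such a change might move the value. Since compound 1 stands at the limit due to the limit of > 20000 nM in this assay, at which 2 of the 2 values shown sit, compound 3 is expected to stay close to that boundary, a step of a number no higher from compound 1 to compound 3 (the limit leaves the size open) that would not be told apart from the scatter. The estimate for compound 3 in this assay is 20000 nM, with a range from 5000 nM to 60000 nM, and a substantial chance that only a limit is reported again.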

Compound 3, half-maximal inhibitory concentration: > 20000 nM
Compound 3 ended at the assay's limit (the forecaster's own chance of this, stated with the estimate: 70%); the middle value lies on the limit itself.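

In this assay compound 3 gives > 20000 nM which is a limit of the assay and not a number. For the compounds shown here, compound 1 also rests on a limit, so no step from compound 1 to compound 3 can be read: the limit of > 20000 nM in this assay, at which 3 of the 3 values shown sit. The compounds shown leave open how strongly any of them inhibits, and whether exchanging acetyl for 3-(ethoxycarbonyl)prop-2-en-1-yl moves the value at all.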